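Swapping Isopropyl for a Pyrrolidinylethyl Arm on Compound 1

A few compounds are considered here, and "the series" means these few. Any claim that something is new, unique, unknown or untested is made for them only; others in the source may bear on it.

Of the compounds shown here, three have so far been measured in a functional assay on BT-474 cells (Homo sapiens) for inhibition; a higher number here means a weaker inhibitor, a lower number a stronger inhibitor. Compound 1 `COc1c(C)cnc(CN2CC(=O)N(C(C)C)c3c(Cl)nc(N)nc32)c1C` gives 30 nM, the lowest number of the three. Compound 3 `Cc1cnc(CN2CC(=O)N(CC(C)C)c3c(Cl)nc(N)nc32)c(C)c1Cl` gives 240 nM, and compound 2 `COc1c(C)cnc(CN2c3nc(N)nc(Cl)c3NC(=O)[C@@H]2C(C)C)c1C` gives 760 nM; both lie beyond the scatter from compound 1, so compound 1 is the strongest inhibitor of the three. Neither compound 2 nor compound 3 differs from compound 1 in a single place, so their gaps carry no isolated structural lesson.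

Compound 4 `COc1c(C)cnc(CN2CC(=O)N(CCN3CCCC3)c3c(Cl)nc(N)nc32)c1C` has not yet been measured. It differs from compound 1 in one spot: 2-(pyrrolidin-1-yl)ethyl in place of isopropyl on an amide-type nitrogen in a ring. For the measured compounds named here, the entering group brings more heavy atoms, a ring and one hydrogen-bond acceptor, but no measured pair in this set shows what such a change does in this assay. The step of a 2.0-fold higher number from compound 1 to compound 4 (0.30 log units; within the scatter) is therefore expected to be modest, leaning toward a slightly higher number, with the direction far from certain. Compound 4 is estimated at 60 nM, within a range from 15 nM to 300 nM.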

Compound 4, half-maximal inhibitory concentration: 520 nM
Compound 4: the middle estimate sits 8.7-fold (0.94 log units) below what was measured; the whole stated range lies below it.
By their numbers in this assay, from the lowest: compound 1; then compound 3; then compounds 4 and 2 (each within the scatter of the next).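

In this assay, for the compounds shown here, putting 2-(pyrrolidin-1-yl)ethyl in place of isopropyl on this amide-type nitrogen gives a 17-fold higher number from compound 1 to compound 4 (1.24 log units; beyond the scatter) and is the first change in the set that can be read at a single place. It shows that this position does not tolerate every group: with the rest of compound 1 unchanged, the larger arm with its ring and hydrogen-bond acceptor goes with a clearly weaker inhibitor. Nothing available here shows which feature of the entering group accounts for this step.

A single step cannot separate the length of the arm from its ring or its nitrogen. As far as these compounds go, it remains open whether 2-cyclopentylethyl, which has carbon in place of that nitrogen, or a shorter 2-(dimethylamino)ethyl arm would give a number closer to compound 1 or to compound 4.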